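This account rests on a few compounds, and the source may have more. Where it says the series, first, only, none or still open, it means among the compounds named here.

Compound 3 `CS(=O)(=O)c1nc(Nc2ccc(C(F)(F)F)c(Cl)c2)c2nc(Nc3c(Cl)cccc3Cl)sc2n1` gives 77 nM in a functional assay on HEK293 cells for antagonist activity at transient receptor potential cation channel subfamily V member 1 (Rattus norvegicus), read by calcium flux (on this read-out lower numbers stand for stronger inhibition and higher numbers for weaker inhibition), the highest of the three numbers recorded; compound 1 `FC(F)(F)c1ccc(Nc2ncnc3sc(Nc4c(Cl)cccc4Cl)nc23)cc1Cl` gives 9 nM and compound 2 `Cc1nc(Nc2ccc(C(F)(F)F)c(Cl)c2)c2nc(Nc3c(Cl)cccc3Cl)sc2n1` gives 2 nM. Compound 4 `FC(F)(F)c1ccc(Nc2nc(-c3ccccc3)nc3sc(Nc4c(Cl)cccc4Cl)nc23)cc1Cl` differs from compound 3 by phenyl in place of methylsulfonyl on an aromatic carbon. Among the measured compounds shown here, two measured steps bear on this change: a 39-fold higher number from compound 2 to compound 3 (1.59 log units; beyond the scatter) and an 8.6-fold higher number from compound 1 to compound 3 (0.93 log units; beyond the scatter), so the leaving methylsulfonyl is tied to the highest number seen here. The entering phenyl carries no hydrogen-bond acceptor, as the methyl in compound 2 and the hydrogen in compound 1 carry none, although it brings more heavy atoms, so the step is expected to move back toward the lower numbers, with wide uncertainty. Compound 4 is therefore estimated at 12 nM, with a range from 2.5 nM to 60 nM, an expected step of a 6.4-fold lower number from compound 3 to compound 4 (0.81 log units; beyond the scatter).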

Compound 4, half-maximal inhibitory concentration: 104 nM
Compound 4: middle estimate off by 8.7-fold (0.94 log units), on the low side; the measured number lies above the stated range.
By their numbers in this assay, from the lowest: compound 2; then compound 1; then compounds 3 and 4 (each within the scatter of the next).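

Swapping methylsulfonyl for phenyl at this position, between two ring nitrogen atoms, gives a 1.4-fold higher number from compound 3 to compound 4 (0.13 log units; within the scatter) in this assay, so carrying hydrogen-bond acceptors or none does not by itself sort the groups here. Phenyl also parts from the two smaller groups, with a 52-fold higher number from compound 2 to compound 4 (1.72 log units; beyond the scatter) and a 12-fold higher number from compound 1 to compound 4 (1.06 log units; beyond the scatter), so a group without acceptors can also sit at the high end. No measurement shown explains this result. The compounds shown leave open where between methyl and phenyl the numbers begin to climb, and how an amine, a methoxy group or an ethyl chain would behave here.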